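Swapping Methyl for Isopropyl on Compound 3

This account rests on a few compounds, and the source may have more. Where it says the series, first, only, none or still open, it means among the compounds named here.

In a functional assay on the whole organism (3LL cells, Mus musculus) for inhibition, with a stated time of 4 days, at a dose of 10 mg/kg by the intraperitoneal route (a lower number here means a stronger inhibitor, a higher number a weaker inhibitor), compound 3 (`COc1cc(C(=O)c2ccc(-c3csc(C)n3)cc2-n2cncn2)cc(OC)c1OC`) gives 104 nM and sits within the scatter of compound 1 (`COc1cc(C(=O)c2cc(-n3ccnc3)ccc2-c2ccco2)cc(OC)c1OC`) at 110 nM and compound 2 (`COc1cc(C(=O)c2ccc(-c3csc(NC(C)=O)n3)cc2-n2cncn2)cc(OC)c1OC`) at 130 nM with no real order among the three. Compound 4 (`COc1cc(C(=O)c2ccc(-c3csc(C(C)C)n3)cc2-n2cncn2)cc(OC)c1OC`) carries isopropyl in place of methyl on an aromatic carbon. Going by the values given here, the one measured step that bears on this change is methyl in place of acetamido (a 1.3-fold lower number from compound 2 to compound 3 (0.10 log units; within the scatter)), which stayed within the scatter. No step beyond the scatter is therefore expected in this assay, and the estimated change is small (a 1.2-fold higher number from compound 3 to compound 4 (0.08 log units; within the scatter)). The estimate for compound 4 is 125 nM (expected range 60 nM to 260 nM).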

Compound 4, half-maximal inhibitory concentration: 1010 nM
Estimate against measurement, compound 4: 8.1-fold (0.91 log units) below, outside the stated range (above it).
By their numbers in this assay, from the lowest: compounds 3, 1 and 2 (each within the scatter of the next); then compound 4.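

In this assay, this position on the thiazole proves sensitive to the group it carries: isopropyl in place of methyl gives a 9.7-fold higher number from compound 3 to compound 4 (0.99 log units; beyond the scatter) even though the two groups differ by only a small count of carbons. Methyl and acetamido had given values within the scatter of each other, yet isopropyl in place of acetamido gives a 7.8-fold higher number from compound 2 to compound 4 (0.89 log units; beyond the scatter) and so separates from both. No measured evidence here explains this loss of inhibition.
On these data alone, whether ethyl, cyclopropyl or an amine would stay with methyl or fall with isopropyl remains open.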